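From phenethyl to 4-fluorophenyl on the sulfur

The compounds below may be only part of what the source reports. "The series", "measured", "known", "first", "only" and "open" are said of these compounds alone.

Compound 1 `CCc1ccc(SCc2ccc(C(=O)Nc3ccccc3N)cc2)cc1` gives 79.1%
Compound 2 `CC(C)(C)c1ccc(SCc2ccc(C(=O)Nc3ccccc3N)cc2)cc1` gives 60.5%
Compound 3 `Nc1ccccc1NC(=O)c1ccc(CSCCc2ccccc2)cc1` gives 81.3%

In a functional assay on HCT-116 cells (Homo sapiens) for inhibition, read by CCK-8 assay, with a stated time of 72 h, tested at 8 uM (a lower number here means less inhibition of growth, a higher number more inhibition of growth at the concentration tested), compound 3 stands at 81.3% and so within the scatter of compound 1, while compound 2 lies clearly lower. Compound 4 `Nc1ccccc1NC(=O)c1ccc(CSc2ccc(F)cc2)cc1` carries 4-fluorophenyl in place of phenethyl on a sulfur and is otherwise the same. The closest measured change is a number 2.2 percentage points higher from compound 1 to compound 3 (within the scatter) on that same sulfur, with phenethyl replacing 4-ethylphenyl. The other, a number 18.6 percentage points lower from compound 1 to compound 2 (beyond the scatter) with tert-butyl in place of ethyl, shows that swapping a group on the aromatic ring can move the number. For the measured compounds named here, no fluorinated compound has been measured yet. Since compound 1, with 4-ethylphenyl on the sulfur, gives 79.1% and sits level with compound 3, no step beyond the scatter is expected. The estimated change is a number 4.3 percentage points lower from compound 3 to compound 4 (within the scatter) in size, a slight drop at most. Compound 4 is expected at 77% with 61% to 89% as its estimated range.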

Compound 4, percent growth inhibition at one concentration: 90.6%
The estimate for compound 4 lay 13.6 percentage points below the measured number; the measured number lies above the stated range.
By their numbers in this assay, from the lowest: compound 2; then compounds 1, 3 and 4 (each within the scatter of the next, the first and the last beyond it).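

In this assay, for the compounds shown here, the group on the aromatic ring now separates three compounds: fluoro in place of ethyl gives a number 11.5 percentage points higher from compound 1 to compound 4 (beyond the scatter) and fluoro in place of tert-butyl gives a number 30.1 percentage points higher from compound 2 to compound 4 (beyond the scatter) as the largest step so far. Against the phenethyl on the sulfur, 4-fluorophenyl shows only a number 9.3 percentage points higher from compound 3 to compound 4 (within the scatter) and so cannot be told apart from it. Nothing available explains these steps. As far as these compounds go, whether an amine or a carboxylic acid in place of the fluoro would keep this level remains open.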